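Sulfoxide series: amide-to-neopentyl swap on the piperidine nitrogen

The source may report more compounds than this note shows. Statements on the series, on what has been measured and on what is new or still open speak of the compounds shown alone.

Measured compounds:
compound 1 `CC(C)(C)C(=O)N1CCC(NCCSC(c2ccc(F)cc2)c2ccc(F)cc2)CC1` gives 163 nM
compound 2 `CC(C)(C)CN1CCC(NCCSC(c2ccc(F)cc2)c2ccc(F)cc2)CC1` gives 315 nM
compound 3 `CC(C)(C)C(=O)N1CCC(NCC[S+]([O-])C(c2ccc(F)cc2)c2ccc(F)cc2)CC1` gives 11200 nM

All three were run in an assay on membranes from Cortex for displacement of a labelled ligand from Sigma non-opioid intracellular receptor 1 (Cavia porcellus), read by scintillation counting, with a stated time of 120 min; on this read-out higher numbers stand for weaker inhibition and lower numbers for stronger inhibition. Compound 1 and compound 2 share one core and differ only in the group on the ring nitrogen, (neopentyl in place of (tert-butyl)carbonyl on an amine nitrogen in a ring), and that change gave a 1.9-fold higher number from compound 1 to compound 2 (0.29 log units; within the scatter). Compound 3 stands apart from both: in this assay it gives the highest number of the three, and the difference between its core and that of compound 1 is not broken down here.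

Compound 4 `CC(C)(C)CN1CCC(NCC[S+]([O-])C(c2ccc(F)cc2)c2ccc(F)cc2)CC1` has not yet been measured. Within the data shown here, it relates to compound 3 by neopentyl in place of (tert-butyl)carbonyl on an amine nitrogen in a ring, which is the same change, at the same place, as the one that separates compound 1 from compound 2. The expectation for compound 4 therefore rests on that earlier step alone: because a 1.9-fold higher number from compound 1 to compound 2 (0.29 log units; within the scatter) stayed within the scatter, a step of about a 1.4-fold higher number from compound 3 to compound 4 (0.15 log units; within the scatter) is expected from the value of compound 3. On that basis compound 4 is estimated at 16000 nM, with a likely range from 5000 nM to 50000 nM.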

Compound 4, inhibition constant: 542 nM
The estimate for compound 4 lay 30-fold (1.47 log units) above the measured number, outside the stated range (below it).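

In this assay, neopentyl in place of (tert-butyl)carbonyl on the amine nitrogen in the ring gives a 21-fold lower number from compound 3 to compound 4 (1.32 log units; beyond the scatter). The size of this change depends on the core that carries it, so a step read on the core of compound 1 cannot be carried over as it stands to the core of compound 3: the same change on two cores in this assay, a 1.9-fold higher number (0.29 log units; within the scatter) from compound 1 to compound 2 and a 21-fold lower number (1.32 log units; beyond the scatter) from compound 3 to compound 4, 40-fold (1.60 log units) apart, beyond the scatter of two such steps This rests on one matched pair per core; it shows that the two cores respond differently, but not why they do, nor how the same change would behave on any further core.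

Open, on these data alone, is whether a large step of this kind also appears with other groups on the ring nitrogen, such as acetyl or a plain methyl, or only with this pair of groups. Also open, as far as these compounds go, is how the same change would behave with a sulfone in place of the sulfoxide, which would show whether the large step is specific to the core of compound 3.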